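Amide in Place of Nitrile on the Fluorinated Side Chain

The source may hold more compounds than are shown below. What is called first, only, known or untested is meant among the compounds shown, and "the series" means these compounds.

Compound 1 `NCCCc1c[nH]c2c(F)cccc12` — 26 nM in an assay on isolated protein for inhibition of Myeloperoxidase (Homo sapiens), read by ELISA, with a stated time of 5 min; a higher number here means a weaker inhibitor, a lower number a stronger inhibitor
Compound 2 `CCCc1c[nH]c2ccc(F)cc12` — > 100 nM, a limit of this assay
Compound 3 `N#CCCCc1c[nH]c2ccc(F)cc12` — 72 nM

Compound 3 gives the higher of the two plain numbers in this assay; compound 1, with 26 nM, sits below it. Compound 2 yields only a limit, > 100 nM. Compound 4 `NC(=O)CCCCc1c[nH]c2ccc(F)cc12` has not been measured; (carbamoylmethyl in place of cyano on a saturated chain carbon, three bonds along the chain from an aromatic carbon). Going by the values given here, the only measured step that bears on this change is an at least 1.3-fold lower number from compound 2 to compound 3 (0.14 log units; that floor lies within the scatter), a small and uncertain move, and no measured pair tests an amide against a nitrile. Compound 4 is therefore expected to give a 1.1-fold lower number from compound 3 to compound 4 (0.04 log units; within the scatter), not beyond the scatter. Compound 4 is estimated at 65 nM, between 25 nM and 160 nM.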

Compound 4, half-maximal inhibitory concentration: 43 nM
Compound 4: middle estimate off by 1.5-fold (0.18 log units), on the high side; the measured number falls inside the stated range.
By their numbers in this assay, from the lowest: compounds 1, 4 and 3 (each within the scatter of the next, the first and the last beyond it). At a limit, above all of these: compound 2.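

In this assay carbamoylmethyl in place of cyano, on a saturated chain carbon three bonds along the chain from an aromatic carbon, gives a 1.7-fold lower number from compound 3 to compound 4 (0.22 log units; within the scatter) and so does not separate the two compounds. Carbamoylmethyl in place of hydrogen gives an at least 2.3-fold lower number from compound 2 to compound 4 (0.36 log units; beyond the scatter) and is the first step at this position to clear the scatter, which the floor for cyano did not. That step is a floor rather than a size, because compound 2 stands at a limit: the limit of > 100 nM in this assay, at which 1 of the 4 values shown sits.

As far as these compounds go, how a carboxylic acid or a longer chain would read at this position remains open. Compound 1 differs from the others in more than one place, so the contribution of its amine cannot be read here.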